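A few compounds are considered here, and "the series" means these few. Any claim that something is new, unique, unknown or untested is made for them only; others in the source may bear on it.

Two compounds of the series have numbers in an assay on HEK293 cells for agonist activity at Bile acid receptor (Homo sapiens); on this read-out lower numbers stand for smaller maximal responses and higher numbers for larger maximal responses. Compound 1 `CCO[C@]1(c2ccc(OCc3c(-c4c(Cl)cccc4Cl)noc3C3CC3)cc2Cl)C[C@H](c2cccc(C(=O)O)c2)C1` gives 89%. Compound 2 `O=C(O)c1cccc(C2CC2c2ccc(OCc3c(-c4c(Cl)cccc4Cl)noc3C3CC3)cc2Cl)c1` gives 87%; of the two numbers this is the lower one, yet compound 1 lies only a little higher, within the usual scatter, so the two cannot be told apart on this read-out. Going by the values given here, no pair of measured compounds differing in a single place is available, so no measured step can be drawn on.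

Compound 3 `O=C(O)c1cncc(C2CC2c2ccc(OCc3c(-c4c(Cl)cccc4Cl)noc3C3CC3)cc2Cl)c1` differs from compound 2 in one place: 5-carboxypyridin-3-yl in place of 3-carboxyphenyl on a saturated ring carbon. Both measured compounds reach a high maximal response, and nothing in those two values speaks for the exchange of 3-carboxyphenyl for 5-carboxypyridin-3-yl moving the response beyond the scatter, so the step of a number 3 percentage points lower from compound 2 to compound 3 (within the scatter) is expected to be about nil or slightly downward. The efficacy of compound 3 in this assay is therefore estimated at 84%, with a range from 68% to 100%.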

Compound 3, largest response reached (reported as efficacy), in percent of the reference or control that the assay uses: 73%
Compound 3: the middle estimate sits 11 percentage points above what was measured; the range from low to high includes it.
By their numbers in this assay, from the lowest: compound 3; then compounds 2 and 1 (each within the scatter of the next).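

In this assay, going by these compounds alone, the exchange of 3-carboxyphenyl for 5-carboxypyridin-3-yl on a saturated ring carbon of the three-membered ring gives the first single-place step: a number 14 percentage points lower from compound 2 to compound 3 (beyond the scatter). This position is therefore not indifferent to the exchange of one ring carbon for nitrogen, even with the carboxylic acid retained, although compound 3 still reaches 73%. No measurement available here bears on the reason for the lower maximal response.

Open, on these data alone, is whether the step belongs to the ring nitrogen as such or to its place in the ring, which a fluorine or a methoxy group on the 3-carboxyphenyl ring could help to separate. Also open, as far as these compounds go, is whether 5-carboxypyridin-3-yl would give a step of similar size on the core of compound 1, and how an amide or a tetrazole in place of the carboxylic acid would read.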